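Working notes: trifluoromethyl in place of hydrogen

The compounds below may be only part of what the source reports. "The series", "measured", "known", "first", "only" and "open" are said of these compounds alone.

Of the compounds shown here, two have been measured so far in a functional assay on HeLa cells (Homo sapiens), with a stated time of 3 days; a higher number here means a weaker inhibitor, a lower number a stronger inhibitor. Compound 1 `O=C(Nc1ccn([C@H]2OCC=CC2=O)c(=O)n1)c1ccccc1` gives 72000 nM, and compound 2 `O=C1C=CCO[C@@H]1n1ccc(O)nc1=O` gives 42000 nM. These two values lie within the scatter of each other, so compound 2 stands level with compound 1 on the present numbers. The two compounds do not form a single-place pair, and neither value indicates how a new group would act on the shared core.

Compound 3 `O=C1C=CCO[C@@H]1n1cc(C(F)(F)F)c(O)nc1=O` is the next entry. Its difference from compound 2 is trifluoromethyl in place of hydrogen on an aromatic carbon, ortho to a hydroxy group. Among the compounds with values here, no measured pair covers a change of this kind, so the expectation has no direct precedent and carries a wide range. A moderate shift towards a lower number in this assay, meaning a stronger inhibitor, is expected, though a result within the scatter would not be surprising. The expected size of the move is a 2.3-fold lower number from compound 2 to compound 3 (0.37 log units; beyond the scatter). For compound 3 the estimated value is 18000 nM, with an expected range of 4000 nM to 60000 nM.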

Compound 3, half-maximal inhibitory concentration: 34000 nM
Compound 3: middle estimate off by 1.9-fold (0.28 log units), on the low side; the range from low to high includes it.
By their numbers in this assay, from the lowest: compounds 3, 2 and 1 (each within the scatter of the next, the first and the last beyond it).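

In this assay, within the data shown here, the series now has its first step in one place, a 1.2-fold lower number from compound 2 to compound 3 (0.09 log units; within the scatter), and this gives the first reading at this position. Trifluoromethyl in place of hydrogen on an aromatic carbon, ortho to a hydroxy group, leaves compound 3 at 34000 nM, level with compound 2 on the present numbers, so this change gives no shift that can be told from the scatter. No supporting measurement on these compounds bears on the reason for this result.

From the compounds shown here alone, whether another group on this aromatic carbon, such as an amine, a carboxylic acid or a longer alkyl chain, would move the number beyond the scatter remains open, since a single step at a single position cannot show how far the position responds to change. Also open, going by these compounds, is whether trifluoromethyl on this carbon would give a similar result on the core of compound 1, where the hydroxy group of compound 2 is replaced.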